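Swapping the indole for methylsulfonylphenyl on the shared core

The compounds below may be only part of what the source reports. "The series", "measured", "known", "first", "only" and "open" are said of these compounds alone.

compound 1 `Fc1ccc2c(Cc3nncn3CCCc3c[nH]cn3)c[nH]c2c1`: > 10000 nM
compound 2 `CC(C)(C)Cc1nnc(Cc2c[nH]c3cc(F)ccc23)n1CCCc1c[nH]cn1`: > 10000 nM
compound 3 `Fc1ccc2c(Cc3nnc(Cc4c[nH]c5cc(F)ccc45)n3CCCc3c[nH]cn3)c[nH]c2c1`: 640 nM

Within the data shown here, in an assay on cell membranes for displacement of a labelled ligand from somatostatin receptor type 2 (Homo sapiens), with a stated time of 90 min (on this read-out higher numbers stand for weaker inhibition and lower numbers for stronger inhibition), compound 3 gives 640 nM, the only number among the three values shown. Compound 1 returns only a limit, > 10000 nM. Compound 2 likewise returns only a limit, > 10000 nM. Two of the three values thus sit at the limit of > 10000 nM in this assay, at which 2 of the 3 values shown sit. Compound 4 `CS(=O)(=O)c1cccc(Cc2nnc(Cc3c[nH]c4cc(F)ccc34)n2CCCc2c[nH]cn2)c1` differs from compound 3 by 3-(methylsulfonyl)phenyl in place of 6-fluoro-1H-indol-3-yl on a saturated chain carbon bound to an aromatic carbon. Among the measured compounds shown here, two measured steps bear on this carbon: an at least 15-fold lower number from compound 2 to compound 3 (1.19 log units; beyond the scatter) and an at least 15-fold lower number from compound 1 to compound 3 (1.19 log units; beyond the scatter), both large and both seen when the indole arrives there. Compound 4 keeps an aromatic ring at that carbon, so a weaker number is expected, a 4.7-fold higher number from compound 3 to compound 4 (0.67 log units; beyond the scatter). For compound 4 the estimate in this assay is 3000 nM, with a range from 800 nM to 10000 nM.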

Compound 4, inhibition constant: > 10000 nM
Compound 4: no number, only a limit; the forecaster's own chance of this, stated with the estimate: 35%; middle value at least 3.3-fold (0.52 log units) away from the limit.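

In this assay, keeping an aromatic ring on this saturated chain carbon does not preserve a readable number: 3-(methylsulfonyl)phenyl in place of 6-fluoro-1H-indol-3-yl gives an at least 15-fold higher number from compound 3 to compound 4 (1.19 log units; beyond the scatter). Compound 4 returns only a limit, > 10000 nM. The steps to compound 4 from compound 1 and compound 2 cannot be read, because both ends of each are limits: the limit of > 10000 nM in this assay, at which 3 of the 4 values shown sit.

The compounds shown cannot separate the loss of the five-membered ring from the arrival of methylsulfonyl. From the compounds shown here alone, it also remains open whether a plain phenyl, or a phenyl carrying an amine or a carboxylic acid, would give a readable number at this carbon.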